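Swapping the aryl group on the triazole of compound 2

The source may report more compounds than this note shows. Statements on the series, on what has been measured and on what is new or still open speak of the compounds shown alone.

Compound 2 `COc1cc2c(Oc3ccc(NC(=O)c4cn(-c5c(Cl)cccc5Cl)nn4)cc3F)ccnc2cc1OCCCN1CCC(C)CC1` has the highest number of the two measured compounds in a functional assay on HT-29 cells (Homo sapiens) for cytotoxicity, read by MTT assay, with a stated time of 72 h (a higher number here means a weaker inhibitor, a lower number a stronger inhibitor), giving 1390 nM. Its nearest neighbour, compound 1 `COc1cc2c(Oc3ccc(NC(=O)c4cn(-c5ccc(F)c(F)c5)nn4)cc3F)ccnc2cc1OCCCN1CCCCC1`, gives 210 nM in this assay, a gap beyond the usual scatter. Compound 3 `COc1cc2c(Oc3ccc(NC(=O)c4cn(-c5ccc(F)c(F)c5)nn4)cc3F)ccnc2cc1OCCCN1CCC(C)CC1` is compound 2 with one change: 3,4-difluorophenyl in place of 2,6-dichlorophenyl on an aromatic nitrogen. Since compound 1 also carries the 3,4-difluorophenyl group, a step towards a lower number is expected, and the estimated step of a 4.3-fold lower number from compound 2 to compound 3 (0.64 log units; beyond the scatter) is beyond the scatter. Compound 3 is therefore expected to give about 320 nM, between 120 nM and 900 nM.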

Compound 3, half-maximal inhibitory concentration: 810 nM
The estimate for compound 3 lay 2.5-fold (0.40 log units) below the measured number, within the range that was stated.
By their numbers in this assay, from the lowest: compound 1; then compounds 3 and 2 (each within the scatter of the next).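

Placing 3,4-difluorophenyl instead of 2,6-dichlorophenyl on this aromatic nitrogen gives a 1.7-fold lower number from compound 2 to compound 3 (0.23 log units; within the scatter), so this assay does not tell these two groups apart here. The step beyond the scatter lies elsewhere in the molecule: methyl in place of hydrogen on a saturated ring carbon gives a 3.9-fold higher number from compound 1 to compound 3 (0.59 log units; beyond the scatter). No evidence at hand explains either step.

Going by these compounds, what a phenyl ring carrying an amine or a carboxylic acid would give on this nitrogen remains open. So does the result for a simple alkyl chain there.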